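Hydroxamate amides: a more polar side chain on compound 1

A few compounds are considered here, and "the series" means these few. Any claim that something is new, unique, unknown or untested is made for them only; others in the source may bear on it.

Measured so far:
compound 1 `CC(C)C(NC(=O)c1ccc(C#Cc2ccccc2)cc1)C(=O)NO`: > 3
compound 2 `O=C(NC1(C(=O)NO)CCCCC1)c1ccc(C#Cc2ccccc2)cc1`: > 3

In a physicochemical assay for lipophilicity (a lower number here means a more polar compound, a higher number a more lipophilic compound), compound 1 gives > 3, which is a limit of the assay and not a number. Compound 2 likewise gives only a limit, > 3. Both shown values thus sit at the limit of > 3 in this assay, at which 2 of the 2 values shown sit, so compound 1 stands at that limit, with no number beneath it.

Compound 3 `O=C(N[C@@H](CO)C(=O)NO)c1ccc(C#Cc2ccccc2)cc1` has not been measured. It differs from compound 1 by a group of 7 heavy atoms (3 carbon, 1 nitrogen, 3 oxygen; no ring) in place of a group of 8 heavy atoms (5 carbon, 1 nitrogen, 2 oxygen; no ring), on an amide-type nitrogen. Among the measured compounds shown here, no measured step between compounds is available here. The step in this assay is expected to run downward, beyond the usual scatter, by a number at least 1.00 log units lower from compound 1 to compound 3 (beyond the scatter). Compound 3 is therefore estimated at 2, within 1.2 to 2.8.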

Compound 3, distribution coefficient: 2
The estimate for compound 3 equals the measured number at the digits printed; low and high end bracket the measured number.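

In this assay compound 1 gives > 3 as a limit of the assay and not a number. Exchanging the 1-(hydroxycarbamoyl)-2-methylpropyl group on the amide-type nitrogen for the group carried by compound 3 gives a number at least 1.00 log units lower from compound 1 to compound 3 (beyond the scatter) as the outcome, so a change at this position can bring the read-out off that limit. Only the lower bound of this step can be read, because compound 1 has no number: the limit of > 3 in this assay, at which 2 of the 3 values shown sit.

One exchange cannot show which part of the new group accounts for the step. On these data alone, what an amine or a carboxylic acid in this side chain would give in this assay stays open.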